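Pyridin-2-yl in place of allyloxy: expected protein binding

The compounds below may be only part of what the source reports. "The series", "measured", "known", "first", "only" and "open" are said of these compounds alone.

Three compounds of the series have been run in an ADME assay on a cell-free system (serum, Bos taurus) for protein binding. Compound 1 `C=CCOc1cc(F)cc(C(=O)NNS(=O)(=O)c2ccccc2F)c1` gives 80.6% in this assay. Compound 2 `Cc1cc(C(=O)NNS(=O)(=O)c2ccccc2F)cc(-n2cc(F)cn2)c1` gives 83.2%, a value within the scatter of that of compound 1, so the two cannot be ordered. Compound 3 `O=C(NNS(=O)(=O)c1ccccc1F)c1cccc(-n2cccn2)c1` gives 36.2%, which leaves a clearly larger unbound fraction than compound 1, a gap beyond the scatter. Among the three, compound 1 therefore holds the second highest unbound fraction, with compound 2 nearest and compound 3 furthest from it. Going by the values given here, no pair of measured compounds differs in one place only, so no single-point step has been measured.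

Compound 4 `O=C(NNS(=O)(=O)c1ccccc1F)c1cc(F)cc(-c2ccccn2)c1` has not yet been measured. It differs from compound 1 as follows: pyridin-2-yl in place of allyloxy on an aromatic carbon. Among the compounds with values here, with no comparable step known, the expectation rests on the spread of the measured values: compound 1 and compound 2 lie high, compound 3 much lower, and compound 4 keeps the fluoro group of compound 1 while carrying an aromatic ring, as compound 3 does. The step expected is a 1.5-fold higher unbound fraction from compound 1 to compound 4 (0.19 log units; within the scatter), a move toward lower binding that may stay within the scatter. Compound 4 is thus estimated at 70%, with a range from 45% to 88%.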

Compound 4, plasma protein binding: 74.9%
The estimate for compound 4 lay 1.2-fold (0.08 log units) (unbound fraction) above the measured number; the measured number falls inside the stated range.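

In this assay the series now has its first single-place step: pyridin-2-yl in place of allyloxy on this aromatic carbon, meta to a fluoro group, gives a 1.3-fold higher unbound fraction from compound 1 to compound 4 (0.11 log units; within the scatter). Compound 1 and compound 4 therefore cannot be ordered, and with the fluoro group kept, this position takes a six-membered aromatic ring with one hetero atom in place of an open chain with a double bond, without a readable change in the read-out. Nothing at hand bears on why the exchange leaves the two compounds level.

Going by these compounds, whether any group at this aromatic carbon can move the read-out beyond the scatter remains open, for instance a carboxylic acid, an amine or a longer alkyl chain. Also open is which structural difference goes with the much lower binding of compound 3 at 36.2%, since no single-place step among the compounds shown connects it to the others, and the part played by the fluoro group beside a constant pyridin-2-yl is equally unresolved.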